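Removing a Methoxy Group Next to the Phenoxy Tail

The compounds below may be only part of what the source reports. "The series", "measured", "known", "first", "only" and "open" are said of these compounds alone.

Of the compounds shown here, three built on one shared core have been tested in an assay on isolated protein for agonist activity at Bile acid receptor (Homo sapiens), read by AlphaScreen, with a stated time of 30 min; on this read-out lower numbers stand for an effect already at smaller amounts and higher numbers for an effect only at larger amounts of compound. Compound 1 `COc1ccccc1-c1ccc([C@H]2S[C@@H](C)C(=O)Nc3c2c(C)nn3-c2ccccc2C)cc1` gives 1100 nM. Compound 2 `COc1ccc(Oc2ccc([C@H]3S[C@@H](C)C(=O)Nc4c3c(C)nn4-c3ccccc3C)cc2)cc1` gives 2200 nM, and the step of a 2.0-fold higher number from compound 1 to compound 2 (0.30 log units; within the scatter) shows that exchanging one aryl tail for another changed little. Compound 3 `COc1cc([C@H]2S[C@@H](C)C(=O)Nc3c2c(C)nn3-c2ccccc2C)ccc1Oc1ccccc1` gives 1900 nM, the second highest of the three numbers; its gaps to compound 2 and to compound 1 both fall within the scatter.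

Compound 4 `Cc1ccccc1-n1nc(C)c2c1NC(=O)[C@H](C)S[C@@H]2c1ccc(Oc2ccccc2)cc1` differs from compound 3 by hydrogen in place of methoxy on an aromatic carbon. Among the compounds with values here, no measured step removes a methoxy group, so the only guide is that the tail of this series has so far tolerated change without movement beyond the scatter. The step of a 1.1-fold higher number from compound 3 to compound 4 (0.02 log units; within the scatter) is therefore expected to be small. Compound 4 is estimated at 2000 nM, within a range from 900 nM to 4500 nM.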

Compound 4, half-maximal effective concentration: 1300 nM
Compound 4: middle estimate off by 1.5-fold (0.19 log units), on the high side; low and high end bracket the measured number.
By their numbers in this assay, from the lowest: compounds 1, 4, 3 and 2 (each within the scatter of the next).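

Removing the methoxy group ortho to a phenoxy group gives a 1.5-fold lower number from compound 3 to compound 4 (0.16 log units; within the scatter) in this assay, so this position keeps its number within the scatter with hydrogen alone on that carbon. The steps of a 1.7-fold lower number from compound 2 to compound 4 (0.23 log units; within the scatter) and a 1.2-fold higher number from compound 1 to compound 4 (0.07 log units; within the scatter) also stay within the scatter, which places the bare phenoxy tail among the other tails shown. Nothing available explains this result.

Still open, on these data alone, is whether an amine or a carboxylic acid on this aromatic carbon would move the number beyond the scatter. As far as these compounds go, a longer chain in place of the methoxy group is equally open.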